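Propargyl to methoxymethyl on the carbinol chain of compound 2

The source may hold more compounds than are shown below. What is called first, only, known or untested is meant among the compounds shown, and "the series" means these compounds.

Measured so far in an assay on isolated protein for inhibition of glucokinase regulatory protein (Homo sapiens), read by AlphaScreen, with stated times of 20 min and 4 h; a lower number here means a stronger inhibitor, a higher number a weaker inhibitor:
compound 1, `CC#C[C@H]1CN(S(=O)(=O)c2ccc(N)nc2)CCN1c1ncc(C(C)(O)C(F)(F)F)s1`, gives 49 nM
compound 2, `C#CCC(O)(c1ccc(N2CCN(S(=O)(=O)c3ccc(N)nc3)C[C@@H]2C#CC)cc1)C(F)(F)F`, gives 6 nM

Compound 2 holds the lowest of the two numbers. Compound 1 sits beyond the scatter from it, and the two differ in more than one place, so their values only show the gap and not its source.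

Compound 3, `CC#C[C@H]1CN(S(=O)(=O)c2ccc(N)nc2)CCN1c1ccc(C(O)(COC)C(F)(F)F)cc1`, keeps everything of compound 2 except one change: methoxy in place of ethynyl on a saturated chain carbon, two bonds along the chain from an aromatic carbon and an oxygen on a saturated carbon. In words, methoxy in place of ethynyl on a saturated chain carbon, two bonds along the chain from an aromatic carbon and an oxygen on a saturated carbon.

Within the data shown here, no measured pair shows this exchange, so no step can be read off. The change is small in count and sits at the end of the chain; a modest move toward a higher number is expected, with a step of a 2.0-fold higher number from compound 2 to compound 3 (0.30 log units; within the scatter) from compound 2 to compound 3 as the working guess. For compound 3 the expected value in this assay is 12 nM, with a range from 4 nM to 40 nM.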

Compound 3, half-maximal inhibitory concentration: 16 nM
Compound 3: the middle estimate sits 1.3-fold (0.12 log units) below what was measured; the range from low to high includes it.
By their numbers in this assay, from the lowest: compound 2; then compound 3; then compound 1.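

In this assay, among these compounds, the exchange of propargyl for methoxymethyl gives the first reading that can be tied to one place, with a 2.7-fold higher number from compound 2 to compound 3 (0.43 log units; beyond the scatter) and a step described as modest. On a saturated chain carbon, two bonds along the chain from an aromatic carbon and an oxygen on a saturated carbon, ethynyl can therefore give way to methoxy at equal heavy-atom count, with a triple bond lost and a hydrogen-bond acceptor gained, while compound 3 still reads 16 nM in this assay. Among the compounds shown here, nothing measured so far speaks to what lies behind this step.

Going by these compounds, the steps linking compound 1 to compound 2 or compound 3 cannot be read, as those pairs differ in more than one place, so the effect of this exchange on the core of compound 1 remains open. Also open, on these data alone, is whether the step follows the loss of ethynyl or the entry of the oxygen, a question that a plain ethyl chain, a nitrile or an amine at the same chain carbon could help to separate.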